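The compounds below may be only part of what the source reports. "The series", "measured", "known", "first", "only" and "open" are said of these compounds alone.

Measured in an ADME assay on L1210 cells (Mus musculus) for cytotoxicity, with a stated time of 48 h; on this read-out lower numbers stand for stronger inhibition and higher numbers for weaker inhibition:
- Compound 1 `C=C1[C@H](C)CCC[C@]1(C)CC/C(C)=C/CC1=C(O)C(=O)C=C(N[C@H](C(=O)O)[C@@H](C)O)C1=O`: > 10 ug/mL (a limit)
- Compound 2 `C=C1[C@H](C)CCC[C@]1(C)CC/C(C)=C/CC1=C(O)C(=O)C=C(NCC(=O)O)C1=O`: 4 ug/mL
- Compound 3 `C=C1[C@H](C)CCC[C@]1(C)CC/C(C)=C/CC1=C(O)C(=O)C=C(N[C@H](C(=O)O)[C@H](C)O)C1=O`: > 10 ug/mL (a limit)

Compound 2 is the only one of these with an exact number. The other two stop at the limit of > 10 ug/mL in this assay, at which 2 of the 3 values shown sit.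

Compound 4 `CC1=CCC[C@](C)(CC/C(C)=C/CC2=C(O)C(=O)C=C(NCC(=O)O)C2=O)[C@@H]1C` has the same atoms as compound 2, joined differently: a group of 9 heavy atoms (9 carbon; one six-membered non-aromatic ring of carbon only) in place of a group of 9 heavy atoms (9 carbon; one six-membered non-aromatic ring of carbon only), on a saturated chain carbon, two bonds along the chain from a double-bonded chain carbon. The group that enters is 1,2,3-trimethylcyclohex-3-en-1-yl, on a saturated chain carbon, two bonds along the chain from a double-bonded chain carbon.

The measured steps all concern another place, a saturated chain carbon bound to an amine nitrogen and a carbonyl carbon. They are an at least 2.5-fold lower number from compound 1 to compound 2 (0.39 log units; beyond the scatter) and an at least 2.5-fold higher number from compound 2 to compound 3 (0.39 log units; beyond the scatter), while a step that the two limits leave unreadable from compound 1 to compound 3 cannot be sized. None of them changes the ring group, so they give no size for this swap. With compound 2 at 4 ug/mL as the only anchor, no step beyond the scatter is expected in this assay. The expected change is no change at the digits printed from compound 2 to compound 4 (within the scatter). For compound 4 the estimated value is 4 ug/mL, with an expected range of 1.5 ug/mL to 9 ug/mL.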

Compound 4, half-maximal inhibitory concentration: 3.5 ug/mL
Compound 4: middle estimate off by 1.1-fold (0.06 log units), on the high side, and the stated range covers the measured number.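

In this assay, putting 1,2,3-trimethylcyclohex-3-en-1-yl on the saturated chain carbon, two bonds along the chain from a double-bonded chain carbon, gives a 1.1-fold lower number from compound 2 to compound 4 (0.06 log units; within the scatter). Going by these compounds alone, this is the first size for a change at this place, since the other readable steps all concern the saturated chain carbon bound to an amine nitrogen and a carbonyl carbon: with the same atoms joined differently in the ring group, compounds 2 and 4 read alike in this one pair. Nothing shown here explains why the two ring groups read alike.

Going by these compounds, whether this holds when 1-hydroxyethyl sits on the carbon bound to the amine nitrogen and the carbonyl carbon remains open. Also open, on these data alone, is what a ring group carrying a hydroxyl, or a methyl on that same carbon, would give.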